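A few compounds are considered here, and "the series" means these few. Any claim that something is new, unique, unknown or untested is made for them only; others in the source may bear on it.

The series shares one core; compound 1 `Cc1ccc(C(C)C)c(OCc2nnc(SCC(=O)Nc3ccc(Cl)cc3)n2Cc2ccccc2)c1` and compound 2 `CC(=O)Nc1ccc(OCc2nnc(SCC(=O)Nc3ccc(S(N)(=O)=O)cc3)n2Cc2ccccc2)cc1` have been measured, while compound 3 `CC(=O)Nc1ccc(OCc2nnc(SCC(=O)Nc3ccc(Cl)cc3)n2Cc2ccccc2)cc1` has not. In a toxicity assay on MT4 cells (Homo sapiens) for cytotoxicity, read by MTT assay, with a stated time of 5 days (a lower number here means that less compound is tolerated, a higher number that more compound is tolerated), compound 1 gives 65.9 ug/mL. For compound 2 this assay reports only a limit, > 125 ug/mL, so compound 2 stands at the limit of > 125 ug/mL in this assay, at which 1 of the 2 values shown sits, rather than at a number. Compound 3 is compound 2 with chloro in place of sulfamoyl on an aromatic carbon. Among the compounds with values here, no measured step covers this change; a downward move in this assay, beyond the usual scatter, is expected because compound 1 with the same chloro group gives 65.9 ug/mL. Compound 3 is estimated at 75 ug/mL, within 35 ug/mL to 125 ug/mL. The expected step is an at least 1.6-fold lower number from compound 2 to compound 3 (0.22 log units; that floor lies within the scatter).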

Compound 3, half-maximal cytotoxic concentration: 14 ug/mL
Estimate against measurement, compound 3: 5.4-fold (0.73 log units) above, and the stated range ends above it.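

On the (4-sulfamoylphenyl)amino side, chloro in place of sulfamoyl gives an at least 8.9-fold lower number from compound 2 to compound 3 (0.95 log units; beyond the scatter) in this assay, so this position alone can move the read-out strongly. Compound 2 enters that step only as a limit of the assay: the limit of > 125 ug/mL in this assay, at which 1 of the 3 values shown sits. With chloro held constant, 4-acetamidophenyl in place of 2-isopropyl-5-methylphenyl on the oxygen gives a 4.7-fold lower number from compound 1 to compound 3 (0.67 log units; beyond the scatter), so the group at the other end also moves the read-out, and in the same assay the number falls.

Still open, going by these compounds, is where other groups at the chloro position, such as methoxy, an amine or a carboxylic acid, would fall relative to compound 2 and compound 3. Also open, on these data alone, is how sulfamoyl behaves alongside 2-isopropyl-5-methylphenyl.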